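Chain shortening at the thioether in a cytotoxicity series

The source may hold more compounds than are shown below. What is called first, only, known or untested is meant among the compounds shown, and "the series" means these compounds.

Measured so far:
- compound 1 `COc1ccc(CNc2nc(SC)nc3ncccc23)cc1`; in a functional assay on CCRF-CEM cells (Homo sapiens) for cytotoxicity, read by MTT assay, with a stated time of 72 h (on this read-out higher numbers stand for lower toxicity in this test and lower numbers for higher toxicity in this test), compound 1 gives > 100000 nM, which is a limit of the assay.
- compound 2 `CCCCCSc1nc(NCc2ccc([Se]C)cc2)c2ccccc2n1`; in this assay compound 2 gives > 100000 nM, again a limit of the assay.

Compound 2 therefore stands at the limit of > 100000 nM in this assay, at which 2 of the 2 values shown sit, so no number is known for it. Compound 3 `CSc1nc(NCc2ccc([Se]C)cc2)c2ccccc2n1` differs from compound 2 by hydrogen in place of butyl on a saturated chain carbon bound to a sulfur. For the measured compounds named here, no step between measured compounds has been followed, so no shift beyond the usual scatter is expected, and the step from compound 2 to compound 3 is estimated as a number no higher from compound 2 to compound 3 (the limit leaves the size open). For compound 3 the estimate in this assay is 100000 nM, with a range from 30000 nM to 300000 nM, most probably reported again only as a limit.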

Compound 3, concentration lethal to 50% of the cells: > 100000 nM
Compound 3 was reported as a limit; the forecaster's own chance of this, stated with the estimate: 75%; the middle value lies on the limit itself.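

Compound 2 and compound 3 are both reported only as limits of the assay, so no step can be read between them: the limit of > 100000 nM in this assay, at which 3 of the 3 values shown sit.

Whether pentylsulfanyl or methylsulfanyl makes any difference in this assay stays open, with no compound shown giving a number.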